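The compounds below may be only part of what the source reports. "The series", "measured", "known", "first", "only" and "open" are said of these compounds alone.

Working notes on the series. In an ADME assay on SH-SY5Y cells (Homo sapiens) for cytotoxicity, read by MTT assay, with a stated time of 48 h (a lower number here means that less compound is needed, a higher number that more compound is needed for the effect), compound 1 (`O=C(NCCCCCCCn1cc(-c2ccc[n+]([O-])c2)nn1)c1ccccc1-c1ccccc1`) gives "not determined" (no result reported) as its entry, so it offers no number for comparison. Compound 2 (`O=C(O)c1ccccc1-c1ccccc1C(=O)NCCCCCCCn1cc(-c2cccnc2)nn1`) gives > 500 nM as its result, and this is a limit and not a number.

Compound 3 (`NC(=O)c1ccccc1-c1ccccc1C(=O)NCCCCCCCn1cc(-c2cccnc2)nn1`) differs from compound 2 in one place: amino in place of hydroxy on a carbonyl carbon (amino in place of hydroxy on a carbonyl carbon, so that 2-carboxyphenyl becomes 2-carbamoylphenyl). Among the compounds with values here, the series holds no measured step between compounds that could serve as a precedent for this change. Resting on compound 2 at > 500 nM as a limit, no change beyond the scatter is expected in this assay and no direction is favoured. The estimated move a step that the limit leaves unreadable from compound 2 to compound 3 is therefore small. Compound 3 is expected at 700 nM in this assay with an estimated range from 300 nM to 2000 nM for a single measurement. A result reported only as a limit is expected to be the likelier outcome.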

Compound 3, half-maximal effective concentration: 289 nM
Beside the measured number, compound 3's estimate is 2.4-fold (0.38 log units) above it; measured number below the stated range.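

Compound 3 gives the series its first single number in this assay, so this position now carries a readable value where compound 1 and compound 2 offered none. Amino in place of hydroxy on a carbonyl carbon, which turns 2-carboxyphenyl into 2-carbamoylphenyl, reads as an at least 1.7-fold lower number from compound 2 to compound 3 (0.23 log units; that floor lies within the scatter), so the direction of the change can be read, while its printed floor does not go beyond the usual scatter of the assay. The full size of the step stays unread because compound 2 is reported only as a limit and not as a number: the limit of > 500 nM in this assay, at which 1 of the 3 values shown sits.

The compounds shown leave open how a methyl ester or a tetrazole would read in this assay in place of the carboxy or carbamoyl group on the same aromatic carbon framework. Also open, going by these compounds, is whether the change from carboxy to carbamoyl would read the same way with a longer chain in the otherwise shared structure, since a single step gives no basis for a pattern across the series.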